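Swapping chloro for nitro on a dichlorophenyl group

The source may report more compounds than this note shows. Statements on the series, on what has been measured and on what is new or still open speak of the compounds shown alone.

Of the compounds shown here, two sharing one core have so far been read in an ADME assay on MT4 cells (Homo sapiens) for cytotoxicity, read by MTT assay; on this read-out higher numbers stand for lower toxicity in this test and lower numbers for higher toxicity in this test. Compound 1 `Cc1ccc(C(=O)N(C(=S)OCCN2C(=O)c3ccccc3C2=O)c2ccc(C)cc2)cc1`, with 4-methylphenyl on the carbonyl carbon, gives 83000 nM. Compound 2 `Cc1ccc(N(C(=O)c2ccc(Cl)c(Cl)c2)C(=S)OCCN2C(=O)c3ccccc3C2=O)cc1`, with 3,4-dichlorophenyl at that place, gives 17000 nM, the lower of the two numbers. Compound 3 `Cc1ccc(N(C(=O)c2ccc(Cl)c([N+](=O)[O-])c2)C(=S)OCCN2C(=O)c3ccccc3C2=O)cc1` differs from compound 2 in one substituent: nitro in place of chloro on an aromatic carbon. This exchange turns 3,4-dichlorophenyl into 4-chloro-3-nitrophenyl. No measurement tests this exchange directly. Among the compounds with values here, the only evidence is the one measured step, a 4.9-fold lower number from compound 1 to compound 2 (0.69 log units; beyond the scatter), which changed the same group more broadly. Compound 3 keeps one of the two chloro groups of compound 2, so a smaller change than that step is expected, most likely a slight move toward higher numbers that may not clear the scatter. The estimated change is a 1.5-fold higher number from compound 2 to compound 3 (0.17 log units; within the scatter). For compound 3 the expected value in this assay is 25000 nM, with an estimated range from 10000 nM to 60000 nM.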

Compound 3, half-maximal cytotoxic concentration: 47000 nM
For compound 3 the middle estimate is 1.9-fold (0.27 log units) below the measured one; the measured number falls inside the stated range.
By their numbers in this assay, from the lowest: compound 2; then compounds 3 and 1 (each within the scatter of the next).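

At this aromatic carbon the exchange is not silent in this assay, since nitro in place of chloro gives a 2.8-fold higher number from compound 2 to compound 3 (0.44 log units; beyond the scatter) even though the other chloro group stays in place, so a change to a single substituent on this ring is enough to move the read-out beyond the scatter. Set against the 4-methylphenyl group, the 4-chloro-3-nitrophenyl group gives a 1.8-fold lower number from compound 1 to compound 3 (0.25 log units; within the scatter), which leaves compound 2 alone at the low end of the series, with its steps to both other compounds beyond the scatter, and shows that a chloro group on the ring does not by itself bring the number down to that of compound 2. Nothing shown explains why nitro and chloro differ here, as no measurement beyond this cytotoxicity read-out bears on the result.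

The three compounds leave open how an amine, a carboxylic acid or a methyl group would read at this same aromatic carbon. They also leave open whether the remaining chloro group is needed at all, since no compound shown carries nitro on this ring without it, and whether the same exchange would give a step of this size on a different core.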